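The compounds below may be only part of what the source reports. "The series", "measured", "known", "first", "only" and "open" are said of these compounds alone.

Going by the values given here, compound 2 `N#Cc1c(Oc2ccc(OC(F)(F)F)cc2)ccnc1N1CCC(NC(=S)Nc2cccnc2)CC1` gives 180 nM in an assay on membranes from brain for binding affinity to Lysophosphatidylserine lipase ABHD12 (Mus musculus), read by fluorescence, with a stated time of 20 min (a lower number here means a stronger inhibitor, a higher number a weaker inhibitor), the lower of the two numbers measured so far. Compound 1 `FC(F)(F)Oc1ccc(Oc2ccnc(N3CCC(NC(=S)Nc4cccnc4)CC3)c2)cc1` gives 410 nM in this assay, and the step of a 2.3-fold lower number from compound 1 to compound 2 (0.36 log units; beyond the scatter) came with the cyano entering. Compound 3 `Cc1c(Oc2ccc(OC(F)(F)F)cc2)ccnc1N1CCC(NC(=S)Nc2cccnc2)CC1` carries methyl in place of cyano on an aromatic carbon. Among the compounds with values here, only that one step bears on the change, and it set cyano against hydrogen, not against methyl, so it gives limited guidance. A modest weakening, partly undoing the gain seen with cyano, is therefore expected, as a step of a 1.7-fold higher number from compound 2 to compound 3 (0.22 log units; within the scatter). Compound 3 is estimated at 300 nM, between 140 nM and 700 nM.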

Compound 3, half-maximal inhibitory concentration: 26 nM
Compound 3: middle estimate off by 12-fold (1.06 log units), on the high side; the whole stated range lies above it.
By their numbers in this assay, from the lowest: compound 3; then compound 2; then compound 1.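

Methyl at this position, ortho to a 4-(trifluoromethoxy)phenoxy group, goes well beyond what cyano gave: the change shows a 6.9-fold lower number from compound 2 to compound 3 (0.84 log units; beyond the scatter) and, set against hydrogen, a 16-fold lower number from compound 1 to compound 3 (1.20 log units; beyond the scatter). The earlier gain with cyano was therefore not the most this position could give, and a substituent here can matter far more than that first step suggested. Nothing measured here accounts for the gap between methyl and cyano.

From the compounds shown here alone, whether an ethyl group, a methoxy group or a chlorine atom would match methyl here remains open. So does whether the gain with methyl holds when other parts of the core change.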